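The source may report more compounds than this note shows. Statements on the series, on what has been measured and on what is new or still open speak of the compounds shown alone.

Working notes on the series. The shared core appears in compound 1 `CC1=C(C(=O)Nc2ccc(Br)cc2)C(c2ccc(Cl)cc2Cl)N=C(SCc2ccccc2)N1` and compound 2 `COc1ccc(C2N=C(SCc3ccccc3)NC(C)=C2C(=O)Nc2ccc(Br)cc2)cc1`. In a functional assay on the whole organism (artery, strain albino) with Rattus norvegicus as the target, with a stated time of 180 min, at a dose of 10 mg/kg by the oral route (a lower number here means less inhibition, a higher number more inhibition at the dose given (going by the name of the read-out)), compound 1 gives 13.4%. In this assay, among the compounds with values here, compound 2 gives 10.3%, which sits at the low end of the two numbers so far, though the step of a number 3.1 percentage points lower from compound 1 to compound 2 (within the scatter), brought about by 4-methoxyphenyl in place of 2,4-dichlorophenyl on a saturated ring carbon, lies within the scatter; on these numbers compound 2 and compound 1 cannot be separated.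

Compound 3 `COc1ccc(C2N=C(SCc3ccc(Cl)cc3)NC(C)=C2C(=O)Nc2ccc(Br)cc2)cc1` is not yet measured. It differs from compound 2 by chloro in place of hydrogen on an aromatic carbon: chloro enters and hydrogen leaves on an aromatic carbon of a six-membered aromatic ring of carbon only, para to a large group; read one bond further out, benzylsulfanyl becomes (4-chlorobenzyl)sulfanyl. Within the data shown here, no measured step touches this part of the molecule; the only step in hand, a number 3.1 percentage points lower from compound 1 to compound 2 (within the scatter), concerns the group on the saturated ring carbon and was within the scatter. Nothing therefore points to a change beyond the scatter in this assay. Compound 3 is expected to shift by a number 1.7 percentage points higher from compound 2 to compound 3 (within the scatter). Compound 3 is estimated at 12%, with a range from 0% to 30%.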

Compound 3, a percentage reported as inhibition, in the whole organism at one dose (the size of the read-out at that dose, not a potency): 22.7%
Estimate against measurement, compound 3: 10.7 percentage points below; low and high end bracket the measured number.
By their numbers in this assay, from the lowest: compounds 2, 1 and 3 (each within the scatter of the next, the first and the last beyond it).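

Within the data shown here, the benzyl ring on the sulfur is the first place where a single change moves the number in this assay beyond the scatter: the step from benzylsulfanyl to (4-chlorobenzyl)sulfanyl gives a number 12.4 percentage points higher from compound 2 to compound 3 (beyond the scatter) and is modest in size. The earlier step, a number 3.1 percentage points lower from compound 1 to compound 2 (within the scatter), concerned the group on the saturated ring carbon and did not separate its two compounds, so a single chloro on an aromatic carbon, para to a large group, has now done what that exchange of aryl groups did not. The data give no explanation for this higher inhibition at the dose given.

As far as these compounds go, it remains open whether the step belongs to chloro itself or would also appear with another group at the same place, such as fluoro, nitro, an amine or a carboxylic acid. Among these compounds, it is equally open whether chloro would give a step of similar size with the 2,4-dichlorophenyl group of compound 1 on the saturated ring carbon, since the one step in hand rests on a single pair with the 4-methoxyphenyl group.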